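Removing the methoxy from compound 3: an expectation

A few compounds are considered here, and "the series" means these few. Any claim that something is new, unique, unknown or untested is made for them only; others in the source may bear on it.

Three amides built on the same core have been measured in a functional assay on the whole organism for inhibition, with Rattus norvegicus as the target, at a dose of 10 mg/kg by the oral route; on this read-out lower numbers stand for a weaker effect and higher numbers for a stronger effect at the one dose given. Compound 1, `COc1cc(C)nc(C(=O)Nc2nn[nH]n2)c1`, gives 20% in this assay. Compound 2, `COc1cccc(C(=O)Nc2nn[nH]n2)n1`, gives 58% in this assay. Compound 3, `COc1cccnc1C(=O)Nc1nn[nH]n1`, gives 0% in this assay, the lowest of the three numbers; its nearest neighbour is compound 1, whose number is higher by a margin beyond the scatter, and the furthest is compound 2, higher by a margin well beyond the scatter.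

Compound 4, `O=C(Nc1nn[nH]n1)c1ccccn1`, has not yet been measured. It differs from compound 3 in one place: hydrogen in place of methoxy on an aromatic carbon.

For the measured compounds named here, no measured pair in this set differs by exactly this change, so the size of the step cannot be read from the data. What can be said is that compound 3, with its methoxy two atoms from the ring nitrogen, sits at 0%, while the other placements of a methoxy on this ring gave higher numbers. The author therefore expects the step of a number 25 percentage points higher from compound 3 to compound 4 (beyond the scatter) to point upward, though of uncertain size. Compound 4 is expected to give about 25% in this assay, with a range from 0% to 60%.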

Compound 4, a percentage reported as inhibition, in the whole organism at one dose (the size of the read-out at that dose, not a potency): 35%
Estimate against measurement, compound 4: 10 percentage points below; the measured number falls inside the stated range.
By their numbers in this assay, from the lowest: compound 3; then compound 1; then compound 4; then compound 2.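

In this assay, hydrogen in place of methoxy on an aromatic carbon, ortho to a group of 8 heavy atoms and two atoms from the ring nitrogen, gives a number 35 percentage points higher from compound 3 to compound 4 (beyond the scatter) and so shows that, at this position, the compound without the methoxy reads higher than the one carrying it. The same exchange made from compound 2, whose methoxy stands elsewhere on the ring, runs the other way, with a number 23 percentage points lower from compound 2 to compound 4 (beyond the scatter) as the step, so among these compounds the direction of the change depends on where the methoxy sits. Nothing shown accounts for either direction.

From the compounds shown here alone, it remains open whether the low number of compound 3 belongs to methoxy alone or would also come with another group at this position, such as an amine, a chlorine atom, a carboxylic acid or the longer ethoxy chain. The separate contribution of the methyl group in compound 1 also stays open, since no compound shown differs from it in that one place.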